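Clearance notes: cyclohexyl in place of isopropyl

The source may report more compounds than this note shows. Statements on the series, on what has been measured and on what is new or still open speak of the compounds shown alone.

In an in vivo ADME assay on the whole organism (strain Sprague-Dawley) for pharmacokinetics, with Rattus norvegicus as the target (a higher number here means faster removal of the compound, a lower number slower removal), compound 1 (`CC(C)[C@@H]1NC[C@@H](C)Oc2ccccc2CCCNC(=O)[C@@H](Cc2ccc(F)cc2)NC(=O)[C@@H](C)N(C)C1=O`) gives 40 mL/min/kg, and compound 2 (`C[C@@H]1CN[C@@H](C2CC2)C(=O)N(C)[C@H](C)C(=O)N[C@H](Cc2ccccc2)C(=O)NCCCc2ccccc2O1`) gives 25 mL/min/kg. For the measured compounds named here, these two values lie within the scatter of each other, so compound 1 stands level with the only other measured member of the series. Going by the values given here, the two compounds differ in more than one place, so the data hold no single-change step to calibrate against. Compound 3 (`C[C@@H]1CN[C@@H](C2CCCCC2)C(=O)N(C)[C@H](C)C(=O)N[C@H](Cc2ccc(F)cc2)C(=O)NCCCc2ccccc2O1`) keeps the core of compound 1 but carries cyclohexyl in place of isopropyl on a saturated ring carbon, next to the ring nitrogen: cyclohexyl in place of isopropyl on a saturated ring carbon. Among the compounds with values here, with no measured step for this change, no shift beyond the scatter is expected in this assay, and no direction can be argued firmly. The expected change is a 1.1-fold higher number from compound 1 to compound 3 (0.05 log units; within the scatter). For compound 3 the estimated value is 45 mL/min/kg, with an expected range of 22 mL/min/kg to 80 mL/min/kg.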

Compound 3, clearance: 43 mL/min/kg
Estimate against measurement, compound 3: 1.0-fold (0.02 log units) above, and the stated range covers the measured number.
By their numbers in this assay, from the lowest: compounds 2, 1 and 3 (each within the scatter of the next).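

In this assay, the series now has its first single-change step, a 1.1-fold higher number from compound 1 to compound 3 (0.03 log units; within the scatter). On this saturated ring carbon next to the ring nitrogen, cyclohexyl in place of isopropyl therefore does not separate the two compounds, even though an all-carbon six-membered ring enters where no ring stood before. No measurement shown bears on the reason for this reading, so no cause can be assigned.

Still open, on these data alone, is how this position responds to a group that is not purely carbon, such as an amine or a carboxylic acid on the same ring carbon. Also open, as far as these compounds go, is whether cyclohexyl in place of isopropyl reads the same way on a background without the 4-fluorobenzyl group.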